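Chain lengthening at the sulfur of compound 1

The compounds below may be only part of what the source reports. "The series", "measured", "known", "first", "only" and "open" are said of these compounds alone.

Compound 1 `CC(C)(Sc1ccncc1Oc1ccc(C#N)c2ccccc12)C(=O)O` gives 5210 nM in an assay on HEK293 cells for inhibition of solute carrier family 22 member 12 (Homo sapiens), read by scintillation counting, with stated times of 30 min and 15 min (a lower number here means a stronger inhibitor, a higher number a weaker inhibitor), the highest of the three numbers in hand. Compound 3 `N#Cc1ccc(Nc2cnccc2SCCCC(=O)O)c2ccccc12` gives 2780 nM, within the scatter of compound 1. Compound 2 `N#Cc1ccc(Nc2cnccc2SCc2ccccc2C(=O)O)c2ccccc12` gives 240 nM, a number well beyond the scatter below compound 1. Among the compounds with values here, the one measured step in this set is a 12-fold higher number from compound 2 to compound 3 (1.06 log units; beyond the scatter); it exchanges an aryl carboxylate for a short chain carboxylate and says nothing about the length of a chain carboxylate.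

Compound 4 `N#Cc1ccc(Oc2cnccc2SCCCCCCC(=O)O)c2ccccc12` is compound 1 with 6-carboxyhexyl in place of 1-carboxy-1-methylethyl on a sulfur. Within the data shown here, no measured pair shows the effect of extending a chain carboxylate on the sulfur; compound 3 and compound 1 carry short chain carboxylates on the sulfur but differ in the linker as well, and their numbers sit within the scatter of each other. The expected step is therefore small, a 1.3-fold lower number from compound 1 to compound 4 (0.11 log units; within the scatter), with a wide spread. Compound 4 is estimated at 4000 nM, between 1500 nM and 11000 nM.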

Compound 4, half-maximal inhibitory concentration: 3780 nM
Beside the measured number, compound 4's estimate is 1.1-fold (0.02 log units) above it; the range from low to high includes it.
By their numbers in this assay, from the lowest: compound 2; then compounds 3, 4 and 1 (each within the scatter of the next).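

On a sulfur whose other neighbours are aromatic carbon, 6-carboxyhexyl in place of 1-carboxy-1-methylethyl gives a 1.4-fold lower number from compound 1 to compound 4 (0.14 log units; within the scatter) in this assay. Within the data shown here, this position therefore accepts an unbranched chain of 9 heavy atoms in place of a branched group of 6 with no change beyond the scatter, which the earlier compounds, differing from compound 1 in more than one place, could not show. No measured evidence bears on this result.

Among these compounds, the single step changes chain length and branching together, so the contribution of each remains open. Also open, on these data alone, is how the core of compound 1 responds to an unbranched carboxylic acid chain shorter than 6-carboxyhexyl, to a 2-carboxyphenyl group on a saturated chain carbon bound to the sulfur, or to a primary amide in place of the carboxylic acid.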